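Swapping the Aryl Group on the Ring Nitrogen

The compounds below may be only part of what the source reports. "The series", "measured", "known", "first", "only" and "open" are said of these compounds alone.

Compound 1 `CNC(=O)c1cc(Oc2ccc(NC(=O)c3nn(-c4ccc(C)cc4)c(=O)cc3C)cc2F)ccn1`: in a functional assay on MCF7 cells (Homo sapiens) for cytotoxicity, read by MTT assay, with a stated time of 72 h (a lower number here means a stronger inhibitor, a higher number a weaker inhibitor), compound 1 gives 8380 nM.
Compound 2 `Cc1cc(=O)n(-c2ccccc2OC(F)(F)F)nc1C(=O)Nc1ccc(Oc2ncnc3ccsc23)cc1`: in this assay compound 2 gives 23800 nM.

Compound 2 stands highest of the two numbers; compound 1, its nearest neighbour, has a lower number, beyond the scatter. The two differ in more than one place, so no single change links them. Compound 3 `Cc1ccc(-n2nc(C(=O)Nc3ccc(Oc4ncnc5ccsc45)cc3)c(C)cc2=O)c(C)c1` departs from compound 2 by one change: 2,4-dimethylphenyl in place of 2-(trifluoromethoxy)phenyl on an aromatic nitrogen. Among the compounds with values here, no measured pair shows this exact exchange, so the expected step in this assay is small and uncertain, leaning toward a modestly lower number. Compound 3 is therefore expected to give 15000 nM, between 5000 nM and 50000 nM. The expected step from compound 2 to compound 3 is a 1.6-fold lower number from compound 2 to compound 3 (0.20 log units; within the scatter).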

Compound 3, half-maximal inhibitory concentration: 11900 nM
The estimate for compound 3 lay 1.3-fold (0.10 log units) above the measured number; measured number inside the range.
By their numbers in this assay, from the lowest: compounds 1, 3 and 2 (each within the scatter of the next, the first and the last beyond it).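

On the aromatic nitrogen, 2,4-dimethylphenyl in place of 2-(trifluoromethoxy)phenyl gives a 2.0-fold lower number from compound 2 to compound 3 (0.30 log units; within the scatter) in this assay. At this position, then, an aryl group of carbon only and one carrying oxygen and fluorine read alike within the scatter. Nothing measured here explains the size of this step. From the compounds shown here alone, whether a phenyl ring bearing an amine or a carboxylic acid on this nitrogen would move the number beyond the scatter stays open. So does whether the same exchange would read alike on the core of compound 1.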